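Benzylpiperazine amides: methyl to methoxy on the benzyl ring

This account rests on a few compounds, and the source may have more. Where it says the series, first, only, none or still open, it means among the compounds named here.

In a functional assay on MCF7 cells (Homo sapiens) for cytotoxicity, read by MTT assay, with a stated time of 24 h, tested at 6.4 ug/mL (on this read-out lower numbers stand for a weaker effect and higher numbers for a stronger effect at the one concentration tested), compound 1 `Cn1c(-c2ccc(NC(=O)CN3CCN(Cc4ccccc4)CC3)cc2)nc(-c2ccccc2)c1-c1ccccc1` gives 23.8%, and compound 2 `Cc1ccc(CN2CCN(CC(=O)Nc3ccc(-c4nc(-c5ccccc5)c(-c5ccccc5)n4C)cc3)CC2)cc1` gives 21.8%. Among the measured compounds shown here, the only measured step, a number 2 percentage points lower from compound 1 to compound 2 (within the scatter), likewise altered a substituent on an aromatic carbon. Compound 2 holds the lowest of the two numbers in this assay, with compound 1 nearest and within the scatter. Compound 3 `COc1ccc(CN2CCN(CC(=O)Nc3ccc(-c4nc(-c5ccccc5)c(-c5ccccc5)n4C)cc3)CC2)cc1` differs from compound 2 by methoxy in place of methyl on an aromatic carbon. For the measured compounds named here, only that one step bears on this change, and it stayed within the scatter. The expected step is a number 0.2 percentage points higher from compound 2 to compound 3 (within the scatter), nothing beyond the scatter. Compound 3 is therefore estimated at 22% in this assay, with a range from 12% to 33%.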

Compound 3, a percentage reported as activity, at one concentration (the size of the read-out at that concentration, not a potency): 29%
For compound 3 the middle estimate is 7 percentage points below the measured one; measured number inside the range.
By their numbers in this assay, from the lowest: compounds 2, 1 and 3 (each within the scatter of the next).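

In this assay, 4-methoxybenzyl in place of 4-methylbenzyl gives a number 7.2 percentage points higher from compound 2 to compound 3 (within the scatter), and methoxy in place of hydrogen at the same carbon gives a number 5.2 percentage points higher from compound 1 to compound 3 (within the scatter). This position has now carried hydrogen, methyl and methoxy, and no step among these three compounds leaves the scatter. Nothing measured here accounts for these numbers.

Open, on these data alone, is whether an amine, a carboxylic acid or a fluorine at this carbon would give a step beyond the scatter. Also open, as far as these compounds go, is how methoxy would read on the benzyl ring at any carbon other than this one.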